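Removing the bromoacrylamide carbonyl: compound 2 to compound 3

This account rests on a few compounds, and the source may have more. Where it says the series, first, only, none or still open, it means among the compounds named here.

Two members of the series have been measured so far in a functional assay on FM3A cells (Mus musculus) for antiproliferative activity, with a stated time of 48 h; on this read-out lower numbers stand for stronger inhibition and higher numbers for weaker inhibition. Compound 1 `C=C(Br)C(=O)Nc1ccc(/C=C/C(=O)c2ccc(C)cc2)cc1` gives 2100 nM in this assay, and compound 2 `C=C(Br)C(=O)Nc1ccc(/C=C/C(=O)c2ccc(OCC)cc2)cc1` gives 680 nM. Among the compounds with values here, the one step between them, a 3.1-fold lower number from compound 1 to compound 2 (0.49 log units; beyond the scatter), concerns the ethoxy in place of methyl on an aromatic carbon. Within the data shown here, on these two numbers compound 2 stands lowest, with compound 1 as its only neighbour.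

Compound 3 `CCOc1ccc(C(=O)/C=C/c2ccc(N)cc2)cc1` is not yet measured. It differs from compound 2 at the other end of the shared core: hydrogen in place of (1-bromoethenyl)carbonyl on a nitrogen on an aromatic ring. Among the measured compounds shown here, no measured step touches this position; the only step in hand sits on the aromatic carbon of the ketone-bearing ring and says nothing about the nitrogen. The change itself is far larger than anything varied so far, so the estimate for compound 3 carries a wide range and is expected to be weaker than compound 2, with a 22-fold higher number from compound 2 to compound 3 (1.34 log units; beyond the scatter) expected as the step.

For compound 3 in this assay the number is estimated at 15000 nM, with a range from 3000 nM to 60000 nM.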

Compound 3, half-maximal inhibitory concentration: 55000 nM
Estimate against measurement, compound 3: 3.7-fold (0.56 log units) below; the range from low to high includes it.
By their numbers in this assay, from the lowest: compound 2; then compound 1; then compound 3.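

In this assay the nitrogen on the aromatic ring proves far more sensitive than the only other place varied so far: hydrogen in place of (1-bromoethenyl)carbonyl gives an 81-fold higher number from compound 2 to compound 3 (1.91 log units; beyond the scatter) whereas ethoxy in place of methyl on an aromatic carbon gave only a 3.1-fold lower number from compound 1 to compound 2 (0.49 log units; beyond the scatter) in the earlier step. The ((1-bromoethenyl)carbonyl)amino to amino change thus counts for much more of the number in this series than the substituent change does, yet the read-out still yields a value for compound 3 at 55000 nM without the group. No measurement at hand explains the size of this step.

The group leaves whole, with its bromine, its carbonyl and both of its double bonds, so the compounds shown do not tell which part carries the step; a plain acetyl group, an unbrominated acryloyl group or a chloroacryloyl group on the same nitrogen would separate these parts. Also open, on these data alone, is whether the step keeps its size when methyl, or a longer alkoxy chain, stands in place of ethoxy on the aromatic carbon.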